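A few compounds are considered here, and "the series" means these few. Any claim that something is new, unique, unknown or untested is made for them only; others in the source may bear on it.

Compound 3 `O=C(Nc1ccc(F)cc1)Nc1cccc(CNc2ncnc3ccccc23)c1` gives 44300 nM in a functional assay on MGC-803 cells (Homo sapiens) for antiproliferative activity, read by MTT assay; on this read-out lower numbers stand for stronger inhibition and higher numbers for weaker inhibition. It sits at one end of the three numbers, yet within the scatter of both neighbours: compound 2 `O=C(Nc1cccc(CNc2ncnc3ccccc23)c1)Nc1ccccc1F` gives 33400 nM and compound 1 `Cc1ccc(NC(=O)Nc2cccc(CNc3ncnc4ccccc34)c2)cc1` gives 31200 nM, with a 1.3-fold higher number from compound 2 to compound 3 (0.12 log units; within the scatter) and a 1.4-fold higher number from compound 1 to compound 3 (0.15 log units; within the scatter). Compound 4 `O=C(Nc1cccc(CNc2ncnc3ccccc23)c1)Nc1cccc(C(F)(F)F)c1` is not yet measured; its change is 3-(trifluoromethyl)phenyl in place of 4-fluorophenyl on an amide-type nitrogen. The steps that swapped the group on this nitrogen earlier, a 1.1-fold higher number from compound 1 to compound 2 (0.03 log units; within the scatter) and a 1.3-fold higher number from compound 2 to compound 3 (0.12 log units; within the scatter), all stayed within the scatter, so no movement beyond the scatter is expected in this assay, although the entering group is larger than any tried so far. Compound 4 is therefore expected to give 35000 nM, with a likely range from 15000 nM to 90000 nM. This amounts to an expected 1.3-fold lower number from compound 3 to compound 4 (0.10 log units; within the scatter).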

Compound 4, half-maximal inhibitory concentration: > 50000 nM
Compound 4: a limit, no number; the forecaster's own chance of this, stated with the estimate: 15%; at least 1.4-fold (0.15 log units) between middle value and limit.
By their numbers in this assay, from the lowest: compounds 1, 2 and 3 (each within the scatter of the next). At a limit, above all of these: compound 4.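

In this assay, compound 4 has a limit of the assay and not a number: the limit of > 50000 nM in this assay, at which 1 of the 4 values shown sits. Only floors can be read from it, an at least 1.1-fold higher number from compound 3 to compound 4 (0.05 log units; that floor lies within the scatter), an at least 1.4-fold higher number from compound 2 to compound 4 (0.17 log units; that floor lies within the scatter) and an at least 1.6-fold higher number from compound 1 to compound 4 (0.20 log units; that floor lies within the scatter), so 3-(trifluoromethyl)phenyl on this amide-type nitrogen is neither shown to match the earlier groups nor shown to differ from them. Within the data shown here, it is the first group here whose real value lies out of reach, which leaves the size of this change unknown.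

Still open, on these data alone, is whether a phenyl ring carrying an amine or a carboxylic acid on this nitrogen would bring the number down beyond the scatter. As far as these compounds go, the shared core stays the same throughout, so changes to it remain open too.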